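A few compounds are considered here, and "the series" means these few. Any claim that something is new, unique, unknown or untested is made for them only; others in the source may bear on it.

Compound 1 `CO[C@@]12CCN(Cc3ccccc3)C[C@H]1[C@H](c1ccc3ccccc3c1)C(C#N)=C(N)O2`: 23400 nM
Compound 2 `CO[C@@]12CCN(C)C[C@H]1[C@H](c1ccc(Cl)cc1Cl)C(C#N)=C(N)O2`: 14900 nM
Compound 3 `CCN1CC[C@@]2(OC)OC(N)=C(C#N)[C@@H](c3ccc(Cl)cc3Cl)[C@@H]2C1`: 27100 nM

All three values come from a functional assay on trachea (Cavia porcellus); a higher number here means a weaker inhibitor, a lower number a stronger inhibitor. Compound 3 stands within the scatter of both others in this assay. Compound 4 `CO[C@@]12CCN(Cc3ccccc3)C[C@H]1[C@H](c1ccc(Cl)cc1Cl)C(C#N)=C(N)O2` differs from compound 3 by phenyl in place of methyl on a saturated chain carbon bound to an amine nitrogen in a ring. Within the data shown here, the only step at this place is a 1.8-fold higher number from compound 2 to compound 3 (0.26 log units; within the scatter), within the scatter. Among the measured compounds shown here, compound 1 also carries a benzyl group on the ring nitrogen but another aryl group, so no step to it is counted; in this assay compound 1 gives 23400 nM, close to the value of compound 3. No change beyond the scatter is expected; the step of a 1.1-fold lower number from compound 3 to compound 4 (0.04 log units; within the scatter) is the estimate. Compound 4 is therefore expected at about 25000 nM, in the range 9000 nM to 70000 nM.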

Compound 4, half-maximal inhibitory concentration: 18300 nM
Compound 4: the middle estimate sits 1.4-fold (0.14 log units) above what was measured; low and high end bracket the measured number.
By their numbers in this assay, from the lowest: compounds 2, 4, 1 and 3 (each within the scatter of the next).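

Phenyl in place of methyl at this place, on a saturated chain carbon bound to an amine nitrogen in a ring, leaves this assay within the scatter (a 1.5-fold lower number from compound 3 to compound 4 (0.17 log units; within the scatter)). Phenyl in place of hydrogen does the same (a 1.2-fold higher number from compound 2 to compound 4 (0.09 log units; within the scatter)), so the methyl, ethyl and benzyl forms are not told apart here. With benzyl held constant, 2,4-dichlorophenyl in place of naphthalen-2-yl on a saturated ring carbon also stays within the scatter (a 1.3-fold lower number from compound 1 to compound 4 (0.11 log units; within the scatter)). No supporting evidence accompanies these steps. From the compounds shown here alone, whether a carboxylic acid or an amine on the benzyl ring, or a longer chain at this place, would move the number beyond the scatter remains open.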